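The source may report more compounds than this note shows. Statements on the series, on what has been measured and on what is new or still open speak of the compounds shown alone.

Compound 1 `CN(C)CCCn1c(=O)n(C2OC(CO)[C@@H](O)[C@H]2O)c2nc(N)nc(O)c21`: 820 uM
Compound 2 `C=CCn1c(=O)n([C@@H](CO)OC(CO)CO)c2nc(N)nc(O)c21`: 37 uM
Compound 3 `C=CCn1c(=[Se])n(C2OC(CO)[C@@H](O)[C@H]2O)c2nc(N)nc(O)c21`: 118 uM

All three were tested in a functional assay with Mus musculus as the target; on this read-out higher numbers stand for an effect only at larger amounts of compound and lower numbers for an effect already at smaller amounts. Compound 1 gives the highest number of the three in this assay, with 820 uM; compound 3 sits nearest to it and compound 2 furthest, and both gaps lie beyond the scatter. Compound 4 `Cn1c(=O)n(C2OC(CO)[C@@H](O)[C@H]2O)c2nc(N)nc(O)c21` has not yet been measured. It differs from compound 1 in one place: hydrogen in place of 2-(dimethylamino)ethyl on a saturated chain carbon bound to an aromatic nitrogen. For the measured compounds named here, no measured pair shows this change by itself, so the expectation rests only on the high starting point of compound 1. A modest downward step is expected, a 2.3-fold lower number from compound 1 to compound 4 (0.37 log units; beyond the scatter), though a result within the scatter would not surprise. Compound 4 is therefore estimated at 350 uM, within a range from 80 uM to 1500 uM.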

Compound 4, concentration for half-maximal effect: 120 uM
Beside the measured number, compound 4's estimate is 2.9-fold (0.46 log units) above it; the range from low to high includes it.
By their numbers in this assay, from the lowest: compound 2; then compounds 3 and 4 (each within the scatter of the next); then compound 1.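

For the compounds shown here, replacing 3-(dimethylamino)propyl with methyl gives a 6.8-fold lower number from compound 1 to compound 4 (0.83 log units; beyond the scatter) in this assay, the first reading of a single change at this position, since the earlier compounds differ from each other in more than one place. So the group carried here does influence the result, and the long amine-bearing chain is not required for an effect. No available data explain this shift.

A plain propyl chain without the amine would help separate the effect of chain length from that of the dimethylamino group. Going by these compounds, it also remains open whether a chain ending in a carboxylic acid would behave like compound 1 or compound 4.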